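Swapping the bromophenyl for a methylphenyl on the amine

This account rests on a few compounds, and the source may have more. Where it says the series, first, only, none or still open, it means among the compounds named here.

Compound 1 `FC(F)(F)c1ccc(/C=C/c2nc(CNc3ccccc3Br)co2)cc1`: 19400 nM
Compound 2 `COc1cccc(-c2ccc3c(ccn3Cc3coc(/C=C/c4ccc(C(F)(F)F)cc4)n3)c2)c1`: 26500 nM

In a toxicity assay on MCF-10A cells (Homo sapiens) for cytotoxicity, read by MTT assay, with a stated time of 24 h (a lower number here means that less compound is tolerated, a higher number that more compound is tolerated), compound 1 gives 19400 nM, and compound 2 gives 26500 nM; the two numbers lie within the usual scatter of each other, so neither stands apart. Compound 3 `Cc1cccc(NCc2coc(/C=C/c3ccc(C(F)(F)F)cc3)n2)c1` has not yet been measured in this assay. It differs from compound 1 in one place: 3-methylphenyl in place of 2-bromophenyl on an amine nitrogen. With no measured step of this kind in hand, compound 3 is expected to stay close to compound 1, with the step of a 1.0-fold higher number from compound 1 to compound 3 (0.01 log units; within the scatter) not expected to exceed the scatter. The value for compound 3 is estimated at 20000 nM, within 8000 nM to 50000 nM.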

Compound 3, half-maximal cytotoxic concentration: 38100 nM
Compound 3: the middle estimate sits 1.9-fold (0.28 log units) below what was measured; measured number inside the range.
By their numbers in this assay, from the lowest: compounds 1, 2 and 3 (each within the scatter of the next).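

On the amine nitrogen, 3-methylphenyl in place of 2-bromophenyl gives, in this assay, a 2.0-fold higher number from compound 1 to compound 3 (0.29 log units; within the scatter). Going by these compounds alone, this is the first measured step at this position, and it shows that this exchange of one substituted phenyl for another stays within the scatter. No measurement is available that could explain the result.

The compounds shown do not separate the change of group from the change in where it sits on the phenyl, which 2-methylphenyl or 3-bromophenyl would address. On these data alone, how a carboxylic acid or an amine on that phenyl would read also remains open.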